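Furan to Methylthiophene on a Bicyclic Amine Core

This account rests on a few compounds, and the source may have more. Where it says the series, first, only, none or still open, it means among the compounds named here.

compound 1 `CCc1csc(CN[C@@H]2C[C@H]3C[C@@H]([C@H]2C)C3(C)C)c1`: 25000 nM
compound 2 `C[C@H]1[C@H](NCc2ccoc2)C[C@H]2C[C@@H]1C2(C)C`: > 100000 nM
compound 3 `C[C@H]1[C@H](NCc2cc(-c3ccccc3)cs2)C[C@H]2C[C@@H]1C2(C)C`: 5000 nM

In an ADME assay on MDCK cells (Canis lupus familiaris) for cytotoxicity, read by microscopy, with a stated time of 48 h (on this read-out higher numbers stand for lower toxicity in this test and lower numbers for higher toxicity in this test), compound 1 gives 25000 nM and compound 3 gives 5000 nM. Compound 2 stands apart: its value is only a limit, (the limit of > 100000 nM in this assay, at which 1 of the 3 values shown sits), so no number is known for it. Compound 4 `Cc1ccsc1CN[C@@H]1C[C@H]2C[C@@H]([C@H]1C)C2(C)C` differs from compound 2 by 3-methylthiophen-2-yl in place of furan-3-yl on a saturated chain carbon bound to an amine nitrogen. Among the measured compounds shown here, the one measured step, a 5.0-fold lower number from compound 1 to compound 3 (0.70 log units; beyond the scatter), concerns a different change and bears only loosely here; it shows that the aromatic substituent can shift the read-out modestly. Compound 1, also carrying a thiophene ring, gives a number rather than a limit. Compound 4 is therefore expected to move by an at least 2.0-fold lower number from compound 2 to compound 4 (0.30 log units; that floor lies within the scatter). Compound 4 is estimated at 50000 nM, between 15000 nM and 200000 nM.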

Compound 4, minimum cytotoxic concentration: 10000 nM
Estimate against measurement, compound 4: 5.0-fold (0.70 log units) above; the whole stated range lies above it.
By their numbers in this assay, from the lowest: compounds 3 and 4 (each within the scatter of the next); then compound 1. At a limit, above all of these: compound 2.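

In this assay the swap of furan-3-yl for 3-methylthiophen-2-yl on a saturated chain carbon bound to an amine nitrogen gives an at least 10-fold lower number from compound 2 to compound 4 (1.00 log units; beyond the scatter) and so shows that the read-out at this place responds to the choice of ring. This step has only a floor, and compound 2 carries a limit rather than a number: the limit of > 100000 nM in this assay, at which 1 of the 4 values shown sits. The compounds shown leave open how much of the step belongs to the ring sulfur in place of oxygen and how much to the methyl. They also leave open how a carboxylic acid on the thiophene ring would read here.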